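This account rests on a few compounds, and the source may have more. Where it says the series, first, only, none or still open, it means among the compounds named here.

Working notes on the series. For the measured compounds named here, in an assay on HEK-293T cells for displacement of a labelled ligand from corticotropin-releasing factor receptor 1 (Homo sapiens), read by scintillation counting, with a stated time of 2 h (on this read-out higher numbers stand for weaker inhibition and lower numbers for stronger inhibition), compound 3 `CCCCN(CC)c1cc(C)nc2c1NC(=O)CN2c1ccc(Cl)cc1Cl` gives 3.4 nM, the highest of the three numbers measured so far. Compound 1 `CCCCN(CC)c1cc(C)nc2c1NC(=O)CN2c1ccc(Br)cc1Br` gives 1.3 nM and compound 2 `CCCCN(CC)c1cc(C)nc2c1NC(=O)CN2c1ccc(Cl)cc1Br` gives 2.5 nM; the steps of a 1.9-fold higher number from compound 1 to compound 2 (0.28 log units; within the scatter) and a 1.4-fold higher number from compound 2 to compound 3 (0.13 log units; within the scatter) each stay within the scatter, while a 2.6-fold higher number from compound 1 to compound 3 (0.42 log units; beyond the scatter) is a modest step beyond it. Compound 4 `CCCCN(CC)c1cc(C)nc2c1NC(=O)CN2c1ccc(C)cc1Br` differs from compound 3 by 2-bromo-4-methylphenyl in place of 2,4-dichlorophenyl on a nitrogen on an aromatic ring in a ring. Going by the values given here, the bromo of the entering 2-bromo-4-methylphenyl has counterparts in compound 1 and compound 2, whereas the methyl has no measured counterpart. Going by the halogen steps alone, a small move toward lower numbers is expected in this assay, a 1.7-fold lower number from compound 3 to compound 4 (0.23 log units; within the scatter), with no certainty that it clears the scatter. Compound 4 is therefore estimated at 2 nM, within a range of 0.8 nM to 5 nM.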

Compound 4, inhibition constant: 4.4 nM
For compound 4 the middle estimate is 2.2-fold (0.34 log units) below the measured one; the range from low to high includes it.
By their numbers in this assay, from the lowest: compounds 1, 2, 3 and 4 (each within the scatter of the next, the first and the last beyond it).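

In this assay, for the compounds shown here, the 2-bromo-4-methylphenyl group brings a methyl on an aromatic carbon, the first group that is not a halogen, and two of its steps stay within the scatter (a 1.3-fold higher number from compound 3 to compound 4 (0.11 log units; within the scatter); a 1.8-fold higher number from compound 2 to compound 4 (0.25 log units; within the scatter)). Going by these compounds alone, only the step from the dibromo compound goes beyond the scatter, and modestly (a 3.4-fold higher number from compound 1 to compound 4 (0.53 log units; beyond the scatter)). Nothing at hand explains this result. Open, going by these compounds, is whether methoxy, trifluoromethyl or an amine in place of that methyl would stay within the same scatter. Also open, on these data alone, is how 2-chloro-4-methylphenyl would read.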